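Half-Life Outlook for Compound 4 after Ring Exchange

The source may hold more compounds than are shown below. What is called first, only, known or untested is meant among the compounds shown, and "the series" means these compounds.

Of the compounds shown here, three built on one shared core have been measured in an ADME assay on microsomes from liver (Homo sapiens) for metabolic stability; a lower number here means that the compound disappears faster, a higher number that the compound lasts longer. Compound 1 `COc1cc(OCc2cccc(-c3ccc(C(F)(F)F)cn3)c2)c2cc(-c3cn4nc(OC)sc4n3)oc2c1` gives 0.733 h. Compound 2 `COc1cc(OCc2cccc(-c3cnc(OC)nc3)c2)c2cc(-c3cn4nc(OC)sc4n3)oc2c1` gives 0.6 h. Compound 3 `COc1cc(OCc2cccc(-c3cncnc3)c2)c2cc(-c3cn4nc(OC)sc4n3)oc2c1` gives 0.117 h, the lowest of the three numbers: a 6.3-fold lower number from compound 1 to compound 3 (0.80 log units; beyond the scatter) and a 5.1-fold lower number from compound 2 to compound 3 (0.71 log units; beyond the scatter) both lie beyond the scatter, whereas a 1.2-fold lower number from compound 1 to compound 2 (0.09 log units; within the scatter) stays within it.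

Compound 4 `COc1cc(OCc2cccc(-c3ccc(C#N)cc3)c2)c2cc(-c3cn4nc(OC)sc4n3)oc2c1` differs from compound 3 in one place: 4-cyanophenyl in place of pyrimidin-5-yl on an aromatic carbon. Going by the values given here, no measured pair exchanges pyrimidin-5-yl for 4-cyanophenyl, so the two steps leading to compound 3 are the only guide. They show that exchanging the aromatic ring at this position, or adding methoxy to it, shifts the half-life by a modest amount, and compound 3, with plain pyrimidin-5-yl, sits at the bottom. Compound 4 is therefore expected to move upward by a 3.0-fold higher number from compound 3 to compound 4 (0.48 log units; beyond the scatter), with wide uncertainty. Compound 4 is estimated at 0.35 h, in a range from 0.12 h to 1 h.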

Compound 4, half-life: > 2 h
Compound 4: a limit, no number; the forecaster's own chance of this, stated with the estimate: 5%; middle value at least 5.7-fold (0.75 log units) away from the limit.
By their numbers in this assay, from the lowest: compound 3; then compounds 2 and 1 (each within the scatter of the next). At a limit, above all of these: compound 4.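

In this assay compound 4 gives > 2 h, which is a limit of the assay and not a number: the limit of > 2 h in this assay, at which 1 of the 4 values shown sits. The earlier ring exchanges at this place left compound 1 and compound 2 within the scatter of each other, whereas 4-cyanophenyl, a ring of carbon only that carries a nitrile, clears both, with an at least 3.3-fold higher number from compound 2 to compound 4 (0.52 log units; beyond the scatter) and an at least 2.7-fold higher number from compound 1 to compound 4 (0.43 log units; beyond the scatter). The widest step at this place is now an at least 17-fold higher number from compound 3 to compound 4 (1.23 log units; beyond the scatter), and all three new steps give only a lower bound on the change.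

The compounds shown do not separate the contribution of the nitrile from that of the ring of carbon only. They also leave open how an amine or a carboxylic acid in place of the nitrile on that ring would read in this assay.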